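A Methyl Added to an Inactive Pair

The source may report more compounds than this note shows. Statements on the series, on what has been measured and on what is new or still open speak of the compounds shown alone.

Measured in a functional assay on CCRF-CEM cells (Homo sapiens) for cytotoxicity, read by cell counting, with a stated time of 3 days; on this read-out lower numbers stand for stronger inhibition and higher numbers for weaker inhibition:
Compound 1 `Cc1ccc(CN2C(=O)S/C(=C\c3ccc(N)cc3)C2=O)cc1` gives > 250000 nM, which is a limit of the assay.
Compound 2 `Nc1cccc(/C=C2\SC(=O)N(Cc3ccccc3)C2=O)c1` gives > 250000 nM, which is a limit of the assay.

Compound 2 therefore stands at the limit of this assay, not at a measured number, and both values shown sit at that same limit (the limit of > 250000 nM in this assay, at which 2 of the 2 values shown sit). Compound 3 `Cc1ccc(CN2C(=O)S/C(=C\c3cccc(N)c3)C2=O)cc1` differs from compound 2 in one place: methyl in place of hydrogen on an aromatic carbon. For the measured compounds named here, no step between measured compounds is available to guide the size of this change. Compound 1 already carries this methyl group on the same part of the shared core and sits at the limit (the limit of > 250000 nM in this assay, at which 2 of the 2 values shown sit), so compound 3 is expected to remain at the limit, with a step from compound 2 of a step that the limit leaves unreadable from compound 2 to compound 3, none beyond the scatter. The estimated value for compound 3 is 300000 nM, with a range from 100000 nM to 1000000 nM.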

Compound 3, half-maximal inhibitory concentration: > 250000 nM
Compound 3 was reported as a limit; the forecaster's own chance of this, stated with the estimate: 85%; the middle value lies beyond the limit too.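

Compound 1, compound 2 and compound 3 all sit at the same limit, so neither the added methyl nor the swap of 4-aminophenyl for 3-aminophenyl gives a step that can be read: the limit of > 250000 nM in this assay, at which 3 of the 3 values shown sit. On these data alone, whether either change would shift a measured number stays open.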